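The source may hold more compounds than are shown below. What is called first, only, known or untested is meant among the compounds shown, and "the series" means these compounds.

Measured so far in a functional assay on HL-60 cells (Homo sapiens) for cytotoxicity, read by MTT assay, with a stated time of 24 h; on this read-out higher numbers stand for weaker inhibition and lower numbers for stronger inhibition:
compound 1 `BrCCCOc1c(Br)cc(Br)cc1Oc1ccc(Br)cc1Br` — 29.9 ug/mL
compound 2 `BrCCCCOc1c(Br)cc(Br)cc1Oc1ccc(Br)cc1Br` — 25.9 ug/mL
compound 3 `BrCCCCCCOc1c(Br)cc(Br)cc1Oc1ccc(Br)cc1Br` — 37.8 ug/mL

Compound 3 shows the highest of the three numbers, but the steps up to it are small: a 1.3-fold higher number from compound 1 to compound 3 (0.10 log units; within the scatter) and a 1.5-fold higher number from compound 2 to compound 3 (0.16 log units; within the scatter). The step between the other two is no larger, a 1.2-fold lower number from compound 1 to compound 2 (0.06 log units; within the scatter). Across the set the bromine-ended chain on the aromatic oxygen is lengthened from three to four to six carbons without any separation in this assay; the three compounds cannot be ranked.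

Compound 4 `COc1c(Br)cc(Br)cc1Oc1ccc(Br)cc1Br` is the next entry. Relative to compound 3 the change is hydrogen in place of 5-bromopentyl on a saturated chain carbon bound to an oxygen on an aromatic ring. This is not a further change of chain length: the whole 5-bromopentyl portion is taken away and only a methyl remains on the oxygen, so the bromine on the chain is lost as well. The measured steps bear on it only indirectly. They show that the length of the chain, with the bromine kept, did not move the number beyond the scatter; none of them removes the bromine. Given that, the expectation for compound 4 is a step of about a 1.2-fold lower number from compound 3 to compound 4 (0.07 log units; within the scatter), that is, no movement beyond the scatter, with a widened range to allow for the untested loss of the chain bromine. Compound 4 is estimated at 32 ug/mL, within 14 ug/mL to 75 ug/mL.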

Compound 4, half-maximal inhibitory concentration: 28.2 ug/mL
Estimate against measurement, compound 4: 1.1-fold (0.05 log units) above; the measured number falls inside the stated range.
By their numbers in this assay, from the lowest: compounds 2, 4, 1 and 3 (each within the scatter of the next).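

In this assay cutting the bromine-ended chain back to a methyl on the aromatic oxygen gives a 1.3-fold lower number from compound 3 to compound 4 (0.13 log units; within the scatter) against the longest chain, a 1.1-fold higher number from compound 2 to compound 4 (0.04 log units; within the scatter) against the four-carbon chain and a 1.1-fold lower number from compound 1 to compound 4 (0.03 log units; within the scatter) against the three-carbon chain, so all three steps stay inside the scatter. The earlier steps shown here all kept the chain bromine, whereas these show that losing the chain and its bromine together does not separate compound 4 from compound 1, compound 2 or compound 3, and the four compounds cannot be ranked. Nothing available here offers an explanation for this flat result.

The compounds shown leave open whether any group on this oxygen can move the number beyond the scatter, for instance an amine or a carboxylic acid in place of the chain bromine, a longer chain, or a hydroxyl in place of the methoxy. They also leave open whether the chain bromine counts for anything on a read-out other than this assay and whether the bromines on the shared core contribute to the number in this series.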